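Swapping the Chalcone Aryl Group in a Lactone Amide Series

A few compounds are considered here, and "the series" means these few. Any claim that something is new, unique, unknown or untested is made for them only; others in the source may bear on it.

Three compounds have been measured in a functional assay on DU-145 cells (Homo sapiens) for antiproliferative activity, read by MTT assay, with a stated time of 72 h; a lower number here means a stronger inhibitor, a higher number a weaker inhibitor:
Compound 1, `CC(C)(C)c1ccc(/C=C/C(=O)c2ccc(OCC(=O)N[C@H]3CCOC3=O)cc2)cc1`, gives 6570 nM.
Compound 2, `O=C(CNc1ccc(Cl)cc1)N[C@H]1CCOC1=O`, gives > 64000 nM, a limit of the assay.
Compound 3, `O=C1OCC[C@@H]1NC(=S)SCCOc1ccccc1Cc1ccccc1`, gives > 64000 nM, also a limit of the assay.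

For the measured compounds named here, compound 1 therefore holds the only number among the three; the other two sit at the limit of > 64000 nM in this assay, at which 2 of the 3 values shown sit. Compound 4, `O=C(COc1ccc(C(=O)/C=C/c2cccc([N+](=O)[O-])c2)cc1)N[C@H]1CCOC1=O`, differs from compound 1 by 3-nitrophenyl in place of 4-(tert-butyl)phenyl on a double-bonded chain carbon bound to a double-bonded chain carbon. Going by the values given here, no pair of measured compounds differing in a single place is available, so the size of this step has no anchor. Compound 4 is expected to stay close to compound 1, with the step of a 1.3-fold lower number from compound 1 to compound 4 (0.12 log units; within the scatter) estimated to lie within the usual scatter. The estimate for compound 4 is 5000 nM, with a range from 1500 nM to 20000 nM.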

Compound 4, half-maximal inhibitory concentration: 41800 nM
The estimate for compound 4 lay 8.4-fold (0.92 log units) below the measured number; the whole stated range lies below it.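

In this assay, the aryl group on a double-bonded chain carbon bound to a double-bonded chain carbon proves sensitive to change: 3-nitrophenyl in place of 4-(tert-butyl)phenyl gives a 6.4-fold higher number from compound 1 to compound 4 (0.80 log units; beyond the scatter). For the compounds shown here, this is the first single-place step, and it runs towards the weaker end. Compound 4 still gives a number rather than a limit, so the scale is not exhausted: the limit of > 64000 nM in this assay, at which 2 of the 4 values shown sit.

On these data alone, whether the step follows from losing the tert-butyl group or gaining the nitro group stays open. A plain phenyl group at this place could separate the two.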